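The source may hold more compounds than are shown below. What is called first, only, known or untested is meant among the compounds shown, and "the series" means these compounds.

Measured so far:
Compound 1, `CC(=O)N[C@H]1CCN(Cc2ccc(OCCCN(C)C)cc2)C1`, gives < 10000 nM in an assay on HEK293 cells for binding affinity to Urotensin-2 receptor (Homo sapiens), read by radioligand binding; a higher number here means a weaker inhibitor, a lower number a stronger inhibitor.
Compound 2, `CC(C)C[C@H](NC(=O)c1cc2ccccc2o1)C(=O)N[C@H]1CCN(Cc2ccc(OCCCN(C)C)cc2)C1`, gives 158 nM in this assay.

For compound 1 the value of < 10000 nM is only a limit of the assay and not a measured number, a point summed up as the limit of < 10000 nM in this assay, at which 1 of the 2 values shown sits. Among the measured compounds shown here, compound 2 is thus the only compound with a real number in this assay, where compound 2 stands at 158 nM. Compound 3, `CC(C)C[C@@H](NC(=O)c1cc2ccccc2o1)C(=O)N[C@H]1CCN(Cc2ccc(OCCCN(C)C)cc2)C1`, differs from compound 2 in one respect: the two compounds have the same atoms and bonds and differ only in configuration as drawn: 1 of 2 stereo elements differ; a stereocentre at a saturated chain carbon is drawn S in compound 2 and R in compound 3. For the measured compounds named here, no step between two measured compounds exists to guide a comparison, so the expectation rests on the structural change alone. Inverting a single stereocentre in a compound of this kind is expected to weaken binding clearly beyond the usual scatter, a step of a 9.5-fold higher number from compound 2 to compound 3 (0.98 log units; beyond the scatter). Compound 3 is accordingly estimated at 1500 nM, with a range from 300 nM to 8000 nM.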

Compound 3, inhibition constant: 3160 nM
For compound 3 the middle estimate is 2.1-fold (0.32 log units) below the measured one; measured number inside the range.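

Among the compounds shown here, until now only one real number was available, so nothing showed how much any single feature of these molecules matters. Redrawing one stereocentre at a saturated chain carbon from S to R gives a 20-fold higher number from compound 2 to compound 3 (1.30 log units; beyond the scatter) in this assay, so the spatial arrangement at this carbon matters strongly, and the S form of this pair is the stronger inhibitor. The gap can be assigned to that arrangement alone because no atom or bond changes: the fact that compounds 2 and 3 differ only in the configuration as drawn.

From the compounds shown here alone, what remains open is how the second stereocentre, drawn the same way in compound 2 and compound 3, affects binding. Also open, going by these compounds, is whether a longer chain, an amine or a carboxylic acid at this carbon would keep or improve the binding seen for compound 2.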